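The source may report more compounds than this note shows. Statements on the series, on what has been measured and on what is new or still open speak of the compounds shown alone.

Three compounds have been measured in a functional assay on MCF7 cells (Homo sapiens) for antiproliferative activity; on this read-out higher numbers stand for weaker inhibition and lower numbers for stronger inhibition:
compound 1 `CCN(C)CCCOc1ccc2cc(NC(=O)c3ccc(O)c(CC=C(C)C)c3)c(=O)oc2c1C` gives 2190 nM;
compound 2 `CC(C)=CCc1cc(C(=O)Nc2cc3ccc(OCCCNCC(C)C)c(C)c3oc2=O)ccc1O` gives 1320 nM;
compound 3 `CC(C)=CCc1cc(C(=O)Nc2cc3ccc(OCCCN(C)C(C)(C)C)c(C)c3oc2=O)ccc1O` gives 1140 nM.

All three share one core and differ only in the group carried by the amine nitrogen at the end of the chain. Among the compounds with values here, compound 3 has the lowest of the three numbers, but its neighbours sit close: a 1.2-fold lower number from compound 2 to compound 3 (0.06 log units; within the scatter) and a 1.9-fold lower number from compound 1 to compound 3 (0.28 log units; within the scatter), so no compound can be set apart from the others. The remaining step, a 1.7-fold lower number from compound 1 to compound 2 (0.22 log units; within the scatter), is just as small.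

Compound 4 `CC(C)=CCc1cc(C(=O)Nc2cc3ccc(OCCCN(C)Cc4ccccc4)c(C)c3oc2=O)ccc1O` carries the change (benzyl in place of tert-butyl on an amine nitrogen). All three measured steps bear on it, since each swaps one substituent on this same amine for another, and none of them moved the number beyond the scatter. No measured compound carries a ring at this position, so the benzyl group is a step into unexplored ground; still, the evidence so far gives no reason to expect a large shift. The step from compound 3 to compound 4 in this assay is therefore expected to be a 1.1-fold lower number from compound 3 to compound 4 (0.06 log units; within the scatter), with no clear direction. Compound 4 is estimated at 1000 nM, with a range from 400 nM to 2500 nM.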

Compound 4, half-maximal inhibitory concentration: 11500 nM
For compound 4 the middle estimate is 12-fold (1.06 log units) below the measured one; measured number outside the range, above it.
By their numbers in this assay, from the lowest: compounds 3, 2 and 1 (each within the scatter of the next); then compound 4.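

In this assay this amine nitrogen proves not to be indifferent to what it carries: benzyl in place of tert-butyl gives a 10-fold higher number from compound 3 to compound 4 (1.00 log units; beyond the scatter) and the other two steps agree, with an 8.7-fold higher number from compound 2 to compound 4 (0.94 log units; beyond the scatter) and a 5.3-fold higher number from compound 1 to compound 4 (0.72 log units; beyond the scatter). Within the data shown here, compounds 1, 2 and 3, whose groups here have no ring, stayed within the scatter of one another, so compound 4, the only one with a ring on this nitrogen, stands apart as the weakest inhibitor of the four. No measurement at hand accounts for this shift.

Since compound 4 alone carries a ring here, the compounds shown leave open whether an aromatic ring is what matters or whether a saturated one, as in a cyclohexylmethyl group, would give the same result. Also open, on these data alone, is how a phenethyl group, with a longer chain leading to the ring, would compare with benzyl.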